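Vanillyl in Place of Dichlorophenyl on the Thioenone Scaffold

The source may report more compounds than this note shows. Statements on the series, on what has been measured and on what is new or still open speak of the compounds shown alone.

Measured compounds:
compound 1 `COc1ccc(/C=C(/Sc2ccc(Br)cc2)C(=O)c2ccc(Br)cc2)cc1` — 25000 nM
compound 2 `O=C(/C(=C\c1ccc(F)cc1F)Sc1ccc(Br)cc1)c1ccc(Br)cc1` — 1000 nM
compound 3 `O=C(/C(=C\c1ccc(Cl)cc1Cl)Sc1ccc(Br)cc1)c1ccc(Br)cc1` — 1000 nM

In a functional assay on DU-145 cells (Homo sapiens) for inhibition, read by trypan blue exclusion, with a stated time of 96 h (a lower number here means a stronger inhibitor of growth, a higher number a weaker inhibitor of growth), compound 3 stands level with compound 2, and the two share the lowest number of the three; compound 1 stands furthest away, as a 25-fold lower number from compound 1 to compound 3 (1.40 log units; beyond the scatter) shows. Compound 4 `COc1cc(/C=C(/Sc2ccc(Br)cc2)C(=O)c2ccc(Br)cc2)ccc1O` is not yet measured. It differs from compound 3 by 4-hydroxy-3-methoxyphenyl in place of 2,4-dichlorophenyl on a double-bonded chain carbon bound to a double-bonded chain carbon. The step that bears on it is a 25-fold lower number from compound 1 to compound 3 (1.40 log units; beyond the scatter). The 4-methoxyphenyl of compound 1 is the closest measured relative of the 4-hydroxy-3-methoxyphenyl that enters. Running that step in reverse, a large rise in this assay is expected for compound 4, roughly a 15-fold higher number from compound 3 to compound 4 (1.18 log units; beyond the scatter), toward the number of compound 1. Compound 4 is therefore estimated at 15000 nM, within 4000 nM to 50000 nM.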

Compound 4, concentration for 50% growth inhibition: 1000 nM
The estimate for compound 4 lay 15-fold (1.18 log units) above the measured number; measured number outside the range, below it.
By their numbers in this assay, from the lowest: compounds 2, 3 and 4 (each within the scatter of the next); then compound 1.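

In this assay, the place on the double-bonded chain carbon takes the 4-hydroxy-3-methoxyphenyl as readily as either halogenated ring (no change at the digits printed from compound 3 to compound 4 (within the scatter); no change at the digits printed from compound 2 to compound 4 (within the scatter)), so halogens are not required there for the lower number. The high number of compound 1 is also not shared by every oxygen-bearing phenyl ring, as the 4-hydroxy-3-methoxyphenyl shows (a 25-fold lower number from compound 1 to compound 4 (1.40 log units; beyond the scatter)). Nothing at hand explains this difference.

The compounds shown leave open whether an amine or a carboxylic acid in place of the hydroxy group of compound 4 would hold this number.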